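Compound 2 and a tert-butyl swap in cell toxicity

The source may hold more compounds than are shown below. What is called first, only, known or untested is meant among the compounds shown, and "the series" means these compounds.

Three compounds built on one shared core have been taken into an ADME assay on L6 cells (Rattus norvegicus) for cytotoxicity, with a stated time of 72 h; a lower number here means a stronger inhibitor, a higher number a weaker inhibitor. There, compound 1 `CC(=O)OC1CC2(N(C)C)CC(c3ccccc3)C1C(c1ccccc1)C2` has the entry "not determined" (no result reported), so it offers no number for comparison. Compound 2 `CC(C)(C)C(=O)OC1CC2(N3CCCC3)CC(c3ccccc3)C1C(c1ccccc1)C2` gives 7620 nM, and compound 3 `CN(C)C12CC(OC(=O)C(C)(C)C)C(C(c3ccccc3)C1)C(c1ccccc1)C2` gives 5060 nM. Among the measured compounds shown here, compound 2 therefore has only one measured neighbour, and the two readings cannot be told apart: the gap is a 1.5-fold lower number from compound 2 to compound 3 (0.18 log units; within the scatter). That step places dimethylamino in place of pyrrolidin-1-yl on a saturated ring carbon.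

Compound 4 `CCN(CC)CC(=O)OC1CC2(N3CCCC3)CC(c3ccccc3)C1C(c1ccccc1)C2` keeps the pyrrolidin-1-yl group of compound 2 and differs elsewhere: (diethylamino)methyl in place of tert-butyl on a carbonyl carbon. In words, (diethylamino)methyl stands in place of tert-butyl on a carbonyl carbon. For the measured compounds named here, no measured pair tests a change at that place, so the single measured step, a 1.5-fold lower number from compound 2 to compound 3 (0.18 log units; within the scatter), bears on it only loosely. It shows one change elsewhere on the core with no effect beyond the scatter, which gives no reason to expect a shift in either direction in this assay. The expected result is a 1.1-fold lower number from compound 2 to compound 4 (0.04 log units; within the scatter), a step no larger than the scatter. On these data alone, for compound 4 the estimated value is 7000 nM, with an expected range from 2500 nM to 20000 nM, kept wide since this kind of change is untested.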

Compound 4, half-maximal inhibitory concentration: 49000 nM
Estimate against measurement, compound 4: 7.0-fold (0.85 log units) below; measured number above the stated range.
By their numbers in this assay, from the lowest: compounds 3 and 2 (each within the scatter of the next); then compound 4.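

In this assay, among the compounds shown here, the group on the carbonyl carbon proves able to move the reading, with a 6.4-fold higher number from compound 2 to compound 4 (0.81 log units; beyond the scatter), whereas the one earlier measured step, at the amine on the saturated ring carbon, stayed within the scatter. Replacing tert-butyl with (diethylamino)methyl adds a nitrogen and a hydrogen-bond acceptor to this group, and the higher number makes compound 4 the weaker inhibitor of the pair, so this ester position is not indifferent to such a swap. No measurement shown here explains why the number rises.

A single pair cannot separate the effect of the added nitrogen from that of the larger group, and a comparison with an all-carbon chain such as n-pentyl, or with a (dimethylamino)methyl group, on the same carbonyl carbon would help to tell these apart. On these data alone, it also remains open whether the same swap would give a similar step on compound 3, which carries dimethylamino instead of pyrrolidin-1-yl.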